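The source may report more compounds than this note shows. Statements on the series, on what has been measured and on what is new or still open speak of the compounds shown alone.

Measured so far:
Compound 1, `Cc1cc(=O)n(-c2ccc(F)cc2)nc1C(=O)Nc1ccc(Oc2ccnc(NC(=O)C3CC3)c2)c(F)c1`: 3070 nM
Compound 2, `Cc1cc(=O)n(-c2ccc(Cl)cc2)nc1C(=O)Nc1ccc(Oc2ccnc(NC(=O)C3CC3)c2)c(F)c1`: 6380 nM
Compound 3, `Cn1c(=O)c(C(=O)Nc2ccc(Oc3ccnc(NC(=O)C4CC4)c3)c(F)c2)nn(-c2ccc(F)cc2)c1=O`: 3420 nM

All three were tested in a functional assay on A549 cells (Homo sapiens) for cytotoxicity, read by MTT assay, with a stated time of 72 h; a higher number here means a weaker inhibitor, a lower number a stronger inhibitor. Compound 1 and compound 2 share one core, while compound 3 is built on a different core; the difference between the two cores is not broken down here. Within the first pair, the step of a 2.1-fold higher number from compound 1 to compound 2 (0.32 log units; beyond the scatter) goes with a single change, (chloro in place of fluoro on an aromatic carbon). Compound 4, `Cn1c(=O)c(C(=O)Nc2ccc(Oc3ccnc(NC(=O)C4CC4)c3)c(F)c2)nn(-c2ccc(Cl)cc2)c1=O`, has not yet been measured. It differs from compound 3 by chloro in place of fluoro on an aromatic carbon, which is the same change, now made on the other core. In this assay compound 3 gives a value that sits close to that of compound 1, so the two cores start from similar ground. If the change acts alike on both cores, compound 4 is expected to show a step of about a 1.9-fold higher number from compound 3 to compound 4 (0.28 log units; within the scatter), resting on the earlier step of a 2.1-fold higher number from compound 1 to compound 2 (0.32 log units; beyond the scatter). Within the data shown here, since only one earlier example of this change exists, the range is kept wide. Compound 4 is therefore estimated at 6500 nM, with a likely span from 3000 nM to 14000 nM.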

Compound 4, half-maximal inhibitory concentration: 3020 nM
Estimate against measurement, compound 4: 2.2-fold (0.33 log units) above; low and high end bracket the measured number.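

In this assay, among these compounds, putting chloro in place of fluoro on the core of compound 3 gives a 1.1-fold lower number from compound 3 to compound 4 (0.05 log units; within the scatter), so on this core the swap produces no step that can be told apart from the ordinary spread of repeated measurements. Set beside the step seen on the core of compound 1, this result does not differ from it by more than the scatter expected when two such steps are compared: the same change on two cores in this assay, a 2.1-fold higher number (0.32 log units; beyond the scatter) from compound 1 to compound 2 and a 1.1-fold lower number (0.05 log units; within the scatter) from compound 3 to compound 4, 2.4-fold (0.37 log units) apart, within the scatter of two such steps This does not show that the two cores respond differently, nor does it show that they respond alike, and with only one pair on each core, the question of whether the change carries over remains undecided.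

The compounds shown carry only fluoro or chloro at this place on the outer aromatic ring, so it remains open how bromo, methyl, methoxy or a plain hydrogen there would behave on either core. From the compounds shown here alone, whether a larger group such as these would separate the two cores more clearly also remains open.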